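Moving the aniline amine on a thiazolidinedione scaffold

This account rests on a few compounds, and the source may have more. Where it says the series, first, only, none or still open, it means among the compounds named here.

The measured compounds are these:
compound 1, `C=C(Br)C(=O)Nc1cccc(/C=C2\SC(=O)N(Cc3cccc(F)c3)C2=O)c1`, 590 nM;
compound 2, `Nc1cccc(/C=C2\SC(=O)N(Cc3cccc(F)c3)C2=O)c1`, 199000 nM;
compound 3, `Nc1cccc(/C=C2\SC(=O)N(Cc3ccccc3)C2=O)c1`, 233000 nM.

All three were tested in a functional assay on L1210 cells (Mus musculus) for cytotoxicity, read by cell counting, with a stated time of 2 days; on this read-out lower numbers stand for stronger inhibition and higher numbers for weaker inhibition. Compound 2 stands second highest of the three numbers: it sits within the scatter of compound 3, whereas compound 1 lies far below it. The step of a 340-fold higher number from compound 1 to compound 2 (2.53 log units; beyond the scatter) is large, and the step of a 1.2-fold higher number from compound 2 to compound 3 (0.07 log units; within the scatter) is within the scatter.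

Compound 4, `Nc1ccc(/C=C2\SC(=O)N(Cc3cccc(F)c3)C2=O)cc1`, is not yet measured. It differs from compound 2 by 4-aminophenyl in place of 3-aminophenyl on a double-bonded chain carbon bound to a double-bonded ring carbon. Going by the values given here, no measured step moves the amine around the ring; the step from compound 1 to compound 2 changes what sits on that nitrogen rather than where it sits, and the step from compound 2 to compound 3 alters a distant fluoro. Neither bears directly on this change, so the data give no guide beyond the fact that both anilines, compound 2 and compound 3, gave high numbers in this assay. Compound 4 is therefore expected to remain high, with a step of a 1.0-fold higher number from compound 2 to compound 4 (0.00 log units; within the scatter) that is not expected to go beyond the scatter in either direction. The estimate for compound 4 is 200000 nM, within 60000 nM to 600000 nM.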

Compound 4, half-maximal inhibitory concentration: 100000 nM
Compound 4: middle estimate off by 2.0-fold (0.30 log units), on the high side; the range from low to high includes it.
By their numbers in this assay, from the lowest: compound 1; then compounds 4, 2 and 3 (each within the scatter of the next, the first and the last beyond it).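

In this assay, going by these compounds alone, the step of a 2.0-fold lower number from compound 2 to compound 4 (0.30 log units; within the scatter) is the first to move the amine around the ring rather than change what sits on it or alter the distant fluoro, and it lies within the scatter. At this level of resolution, 3-aminophenyl and 4-aminophenyl on the double-bonded chain carbon cannot be told apart, so the position of the unsubstituted amine has shown no measurable bearing on the read-out, while the large step of a 340-fold higher number from compound 1 to compound 2 (2.53 log units; beyond the scatter) remains the only one beyond the scatter and concerns the group on the nitrogen. No measurement at hand offers an explanation for why the two placements read alike.

From the compounds shown here alone, what remains open is whether the placement would matter once the nitrogen carries (1-bromoethenyl)carbonyl, since that group appears here only on 3-aminophenyl, and a difference between placements could emerge only in that more active range. It is equally unsettled how a smaller acetyl on the nitrogen, or a hydroxyl or carboxylic acid in place of the amine, would read in this assay at either placement.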